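The source may report more compounds than this note shows. Statements on the series, on what has been measured and on what is new or still open speak of the compounds shown alone.

Compound 1 `Cc1cc(C)c2cccc(OCc3c(Cl)ccc(S(=O)(=O)NC4(C(=O)N5CCN(C(=O)[C@@H](N)CCCCN)CC5)CCCC4)c3Cl)c2n1` — in an assay on isolated protein for binding affinity to B1 bradykinin receptor (Homo sapiens) (on this read-out lower numbers stand for stronger inhibition and higher numbers for weaker inhibition), compound 1 gives < 10000 nM, which is a limit of the assay.
Compound 2 `Cc1cc(C)c2cccc(OCc3c(Cl)ccc(S(=O)(=O)NC4(C(=O)N5CCN(C(=O)[C@@H](N)CCCC[N+](C)(C)C)CC5)CCCC4)c3Cl)c2n1` — in this assay compound 2 gives < 10000 nM, likewise a limit.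
Compound 3 `Cc1cc(C)c2cccc(OCc3c(Cl)ccc(S(=O)(=O)NC4(C(=O)N5CCN(C(=O)[C@H](CCCC[N+](C)(C)C)[N+](C)(C)C)CC5)CCCC4)c3Cl)c2n1` — in this assay compound 3 gives < 10000 nM, again a limit.

Compound 3 thus sits at the same limit as the other two measured compounds: the limit of < 10000 nM in this assay, at which 3 of the 3 values shown sit. The steps a step that the two limits leave unreadable from compound 1 to compound 2 and a step that the two limits leave unreadable from compound 2 to compound 3 accordingly have no readable size. Compound 4 `Cc1cc(C)c2cccc(OCc3c(Cl)ccc(S(=O)(=O)NC4(C(=O)N5CCN(C(=O)[C@H](CCCCN)[N+](C)(C)C)CC5)CCCC4)c3Cl)c2n1` differs from compound 3 by one nitrogen atom in place of a group of 4 heavy atoms (3 carbon, 1 nitrogen; no ring), on a saturated chain carbon, five bonds along the chain from an amine nitrogen and a carbonyl carbon. Only these two steps bear on this change, and neither yields a size or direction, so nothing beyond the scatter can be read from them. The estimate for compound 4 in this assay is 800 nM, within 40 nM to 10000 nM, with a fair chance that again only the limit is reported. The expected step that the limit leaves unreadable from compound 3 to compound 4 is accordingly set at no change beyond the scatter.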

Compound 4, inhibition constant: < 10000 nM
Compound 4: only a limit was reported; the forecaster's own chance of this, stated with the estimate: 60%; the middle value lies beyond the limit too.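

No step involving compound 4 can be read against compound 1, compound 2 or compound 3, as all four sit at one limit: the limit of < 10000 nM in this assay, at which 4 of the 4 values shown sit.

The compounds shown leave open how the four differ in this assay, and whether amino in place of the group of 4 heavy atoms changes binding at all.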